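The source may report more compounds than this note shows. Statements on the series, on what has been measured and on what is new or still open speak of the compounds shown alone.

Among the measured compounds shown here, compound 2 `COc1ccc(-c2cc(NNC(=O)Nc3cc(Cl)nc(OC(C)C)c3)nc3c2cnn3C)cc1` gives 2320 nM in an assay on isolated protein for binding affinity to sphingosine 1-phosphate receptor 2 (Homo sapiens), read by surface plasmon resonance (a higher number here means weaker binding, a lower number tighter binding), the higher of the two numbers measured, its only neighbour being compound 1 `COc1ccc(-c2cc(NNC(=O)Nc3cc(Cl)nc(Cl)c3)nc3c2cnn3C)cc1`, which gives 520 nM in this assay. For the measured compounds named here, the single step between them, a 4.5-fold higher number from compound 1 to compound 2 (0.65 log units; beyond the scatter), exchanged a chloro for an isopropoxy group on the aromatic carbon and is the only measured change that bears on compound 3 `COc1ccc(-c2cc(NNC(=O)Nc3cc(Br)nc(Br)c3)nc3c2cnn3C)cc1`. Compound 3 differs from compound 2 by 2,6-dibromopyridin-4-yl in place of 2-chloro-6-isopropoxypyridin-4-yl on an amide-type nitrogen. That change undoes the isopropoxy substitution seen in the step from compound 1 and replaces both chlorines by bromines, so the step from compound 1 to compound 2 is the relevant guide, read in reverse. A return to roughly the level of compound 1 is therefore expected, and the step from compound 2 to compound 3 is expected to be a 3.9-fold lower number from compound 2 to compound 3 (0.59 log units; beyond the scatter), a drop beyond the scatter. Compound 3 is accordingly estimated at 600 nM, within a range of 250 nM to 1500 nM.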

Compound 3, dissociation constant: 6320 nM
Estimate against measurement, compound 3: 11-fold (1.02 log units) below; the measured number lies above the stated range.
By their numbers in this assay, from the lowest: compound 1; then compound 2; then compound 3.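

The pyridinyl group on the amide-type nitrogen tolerates less than the first step suggested: in this assay, 2,6-dibromopyridin-4-yl in place of 2,6-dichloropyridin-4-yl gives a 12-fold higher number from compound 1 to compound 3 (1.08 log units; beyond the scatter), so the two chlorines cannot be exchanged for bromines without a large loss of binding. Losing the isopropoxy group did not by itself bring back the level of compound 1, since the change to the dibromo group gives a 2.7-fold higher number from compound 2 to compound 3 (0.44 log units; beyond the scatter) instead. Binding at this position therefore depends on which halogen is present, and not only on the absence of isopropoxy. No evidence is available that explains this result.

The compounds shown leave open how a single bromo paired with a chloro or with isopropoxy would behave. They also do not show whether a fluoro, methyl or amino group in place of a chloro would keep or lose binding.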